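The source may hold more compounds than are shown below. What is called first, only, known or untested is meant among the compounds shown, and "the series" means these compounds.

In a functional assay on J774 cells (Mus musculus) for cytotoxicity, read by resazurin assay (a higher number here means a weaker inhibitor, a lower number a stronger inhibitor), three compounds have been measured:

compound 1 `OCCCCCC(O)c1ccc(-c2ccc(OC(F)(F)F)cc2)cc1` gives 14000 nM
compound 2 `O=C(CCCCCO)c1ccc(-c2ccc(F)cc2F)cc1` gives 6000 nM
compound 3 `Cc1cc(F)ccc1-c1ccc(C(=O)CCCCCO)cc1` gives 20000 nM

Compound 3 and compound 1 lie within the usual scatter of each other, so these two cannot be ranked. Among the measured compounds shown here, compound 2 stands apart from compound 3, as the one measured step shows: a 3.3-fold higher number from compound 2 to compound 3 (0.52 log units; beyond the scatter) when methyl takes the place of fluoro on an aromatic carbon.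

The next compound to consider is compound 4 `O=C(CCCCCO)c1ccc(-c2ccc(F)cc2Cl)cc1`, which differs from compound 3 in one place: chloro in place of methyl on an aromatic carbon. This is chloro in place of methyl on an aromatic carbon, ortho to a large group and meta to a fluoro group. Compound 1 differs from the others in more than one place, so it offers no direct comparison. For the measured compounds named here, no chloro compound has been measured yet, which leaves only the step at that same carbon as a guide. With compound 2 at 6000 nM and compound 3 at 20000 nM as the two measured ends, chloro is expected to land somewhere between them. The estimated change in this assay is a small one toward a lower number: a 1.8-fold lower number from compound 3 to compound 4 (0.26 log units; within the scatter), possibly no larger than the scatter. For compound 4 the expected value is 11000 nM with an estimated range from 5000 nM to 22000 nM as the likely span.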

Compound 4, half-maximal inhibitory concentration: 15000 nM
Compound 4: middle estimate off by 1.4-fold (0.13 log units), on the low side; the range from low to high includes it.
By their numbers in this assay, from the lowest: compound 2; then compounds 1, 4 and 3 (each within the scatter of the next).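

In this assay, putting chloro in place of methyl on this aromatic carbon, ortho to a large group and meta to a fluoro group, gives a 1.3-fold lower number from compound 3 to compound 4 (0.12 log units; within the scatter), so these two groups cannot be told apart at this position. Fluoro now stands alone among the three groups tried here: a 2.5-fold higher number from compound 2 to compound 4 (0.40 log units; beyond the scatter), which sits beside the earlier 3.3-fold higher number from compound 2 to compound 3 (0.52 log units; beyond the scatter), so two different replacements of fluoro at this carbon both end beyond the scatter, on the side of the higher number. The result therefore shows more than a single methyl step could, as the gap from compound 2 is not confined to methyl, but nothing available explains why fluoro differs from the other two groups.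

As far as these compounds go, only fluoro, chloro and methyl have been compared at this carbon, so it remains open where a plain hydrogen, a methoxy group, a trifluoromethyl group or a nitrile would fall. From the compounds shown here alone, whether the same gap would appear with an amine or a carboxylic acid at the end of the chain in place of the hydroxyl group also remains open.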